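This account rests on a few compounds, and the source may have more. Where it says the series, first, only, none or still open, it means among the compounds named here.

In an ADME assay on microsomes from liver (Rattus norvegicus) for metabolic stability (a lower number here means that the compound disappears faster, a higher number that the compound lasts longer), compound 1 `CC(C)C(/C=C1\NC(=O)NC1=O)c1ccc(-c2ccc3cccc(F)c3c2)[nH]c1=O` gives 1.46 h. Going by the values given here, compound 2 `O=C1NC(=O)/C(=C/C(c2ccc(-c3ccc4cccc(F)c4c3)[nH]c2=O)C2CCCCC2)O1` gives 2.39 h, and these two numbers lie within the usual scatter of each other, so compound 1 cannot be told apart from the only other compound with a true number. Compound 3 `CC(C)(/C=C1\OC(=O)NC1=O)c1ccc(-c2ccc3cccc(F)c3c2)[nH]c1=O` is reported as > 3 h, which is a limit of the assay and not a number.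

The next compound to be tested is compound 4 `CC(C)C(/C=C1/C(=O)NC(=O)N1C)c1ccc(-c2ccc3cccc(F)c3c2)[nH]c1=O`. It differs from compound 1 in one place: methyl in place of hydrogen on an amide-type nitrogen in a ring, with methyl in place of hydrogen on an amide-type nitrogen in a ring. Among the compounds with values here, no pair of measured compounds shows this change, so the data offer no direct guide to its effect in this assay. The expectation therefore stays close to compound 1 at 1.46 h, with no shift beyond the scatter. The expected size of the change is a 1.0-fold lower number from compound 1 to compound 4 (0.02 log units; within the scatter), which is within the scatter. For compound 4 the estimated half-life is 1.4 h, with an expected range from 0.7 h to 2.8 h.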

Compound 4, half-life: 1.08 h
Estimate against measurement, compound 4: 1.3-fold (0.11 log units) above; the range from low to high includes it.
By their numbers in this assay, from the lowest: compounds 4, 1 and 2 (each within the scatter of the next, the first and the last beyond it). At a limit, above all of these: compound 3.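

In this assay, going by these compounds alone, the step at this position reads a 1.4-fold lower number from compound 1 to compound 4 (0.13 log units; within the scatter), the first direct reading of any change on this amide-type ring nitrogen. Methyl in place of the hydrogen therefore gives a half-life that cannot be told apart from that of compound 1, so this nitrogen takes the one added carbon without a change that stands out from the scatter. This rests on a single step, and the data assign no cause to it.

The compounds shown leave open whether a larger group on this nitrogen, such as an ethyl group, a longer chain or a chain carrying an amine, would behave as methyl does. Compound 3 remains a limit of the assay and not a number, and so it cannot be placed exactly: the limit of > 3 h in this assay, at which 1 of the 4 values shown sits.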